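The source may report more compounds than this note shows. Statements on the series, on what has been measured and on what is new or still open speak of the compounds shown alone.

In an ADME assay on CCRF-HSB-2 cells (Homo sapiens) for cytotoxicity, with a stated time of 7 days (a lower number here means that less compound is tolerated, a higher number that more compound is tolerated), compound 1 `COCCOc1nc(N)nc2c1ncn2/C=C1/CC1(CO)CO` is reported only as a limit, > 20000 nM. Compound 2 `CCCCOc1nc(N)nc2c1ncn2/C=C1/CC1(CO)CO` is likewise reported only as a limit, > 20000 nM. Within the data shown here, the one measured step, a step that the two limits leave unreadable from compound 1 to compound 2, therefore has no readable size, and all that can be said is the limit of > 20000 nM in this assay, at which 2 of the 2 values shown sit. Compound 3 `Nc1nc(SCc2ccccc2)c2ncn(/C=C3/CC3(CO)CO)c2n1` changes the same site on the shared core: benzylsulfanyl in place of butoxy on an aromatic carbon. In words, benzylsulfanyl stands in place of butoxy on an aromatic carbon. Among the measured compounds shown here, the entering group brings a six-membered aromatic ring of carbon only, and no measured step covers such a swap, so no measured size can be carried over. In this assay, no step beyond the usual scatter is therefore expected, and the estimated change is an at least 1.3-fold lower number from compound 2 to compound 3 (0.12 log units; that floor lies within the scatter). The estimate for compound 3 is 15000 nM, with an expected range of 4000 nM to 40000 nM.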

Compound 3, half-maximal cytotoxic concentration: > 100000 nM
Compound 3 gave a limit, no number; the forecaster's own chance of this, stated with the estimate: 60%; middle value at least 6.6-fold (0.82 log units) from the limit.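

No step can be read from compound 3 to compound 1 or compound 2, since all three give only limits in this assay. Left open is the concentration at which any of them reaches half-maximal cytotoxicity, and whether swapping these groups changes it.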